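Pyridinyl for Phenyl: Expected Tissue Distribution of Compound 3

The source may report more compounds than this note shows. Statements on the series, on what has been measured and on what is new or still open speak of the compounds shown alone.

Compound 1, `Cc1cc(C(=O)Nc2ccccc2)nn1Cc1cc(Cl)ccc1OCc1ccccc1`: in an in vivo ADME assay on the whole organism for pharmacokinetics, with Rattus norvegicus as the target (on this read-out higher numbers stand for wider distribution into tissues and lower numbers for narrower distribution), compound 1 gives "not determined" (no result reported).
Compound 2, `Cc1cc(C(=O)NCc2ccccc2)nn1Cc1cc(Cl)ccc1OCc1ccccc1`: in this assay compound 2 gives 9.3 L/kg.

Compound 2 therefore stands on the only number shown in this assay; compound 1 carries no number there, so no step between measured compounds is available. Compound 3, `Cc1cc(C(=O)NCc2ccccn2)nn1Cc1cc(Cl)ccc1OCc1ccccc1`, differs from compound 2 in one place: pyridin-2-yl in place of phenyl on a saturated chain carbon bound to an amide-type nitrogen. The amide, the core of compound 2 and the remainder of the molecule are unchanged.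

Without a measured step to rest on, the expectation for this assay must lean on compound 2 alone, which gave 9.3 L/kg. A modest narrowing of distribution is expected, of a size that may not rise above the usual scatter of repeated measurements. Compound 3 is estimated to give 6 L/kg, with a range from 2.5 L/kg to 14 L/kg. That estimate corresponds to an expected step of a 1.6-fold lower number from compound 2 to compound 3 (0.19 log units; within the scatter).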

Compound 3, volume of distribution at steady state: 3.6 L/kg
For compound 3 the middle estimate is 1.7-fold (0.22 log units) above the measured one; the measured number falls inside the stated range.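

In this assay, going by these compounds alone, the exchange of phenyl for pyridin-2-yl on a saturated chain carbon bound to an amide-type nitrogen gives a 2.6-fold lower number from compound 2 to compound 3 (0.41 log units; beyond the scatter) and provides the first readable step at this position. It shows that tissue distribution responds to a change at this place, even though the heavy-atom count stays the same and the only counted differences are a ring nitrogen in place of a carbon and the hydrogen-bond acceptor that enters with it. Nothing measured here explains the size or direction of this step.

Any step involving compound 1 cannot be read, so the contribution of the chain carbon remains unknown. The compounds shown also leave open whether pyridin-3-yl or pyridin-4-yl at this place, or an amine or a carboxylic acid on the ring, would move the number as far.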